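Aryl versus tert-butyl on the ring nitrogen

This account rests on a few compounds, and the source may have more. Where it says the series, first, only, none or still open, it means among the compounds named here.

Compound 1 `COc1ccc(Cc2nn(-c3ccccc3)c(=O)c3ccccc23)cc1OC` — in a functional assay on aorta with Alpha-1D adrenergic receptor (Rattus norvegicus) as the target (a lower number here means that less compound is needed, a higher number that more compound is needed for the effect), compound 1 gives > 100000 nM, a limit of the assay.
Compound 2 `COc1ccc(Cc2nn(C(C)(C)C)c(=O)c3ccccc23)cc1OC` — in this assay compound 2 gives 10000 nM.
Compound 3 `Oc1nnc(Cc2ccc3ccccc3c2)c2ccccc12` — in this assay compound 3 gives > 10000 nM, a limit of the assay.

Among the compounds with values here, compound 2 holds the only finite number in the set; the other two values are limits. Compound 1 sits at the limit of > 100000 nM in this assay, at which 1 of the 3 values shown sits. Compound 3 sits at the limit of > 10000 nM in this assay, at which 1 of the 3 values shown sits. Within the data shown here, the one measured step that links two of these structures, an at least 10-fold lower number from compound 1 to compound 2 (1.00 log units; beyond the scatter), concerns tert-butyl in place of phenyl on an aromatic nitrogen. Among the measured compounds shown here, compound 3 differs from the others in more than one place and yields no step of its own.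

Compound 4 `COc1ccc(Cc2nn(-c3ccc([N+](=O)[O-])cc3)c(=O)c3ccccc23)cc1OC` runs that change in reverse: 4-nitrophenyl in place of tert-butyl on an aromatic nitrogen. For the measured compounds named here, only the step from compound 1 to compound 2 bears on this move; there an aryl group on that nitrogen went with a value at the limit, and 4-nitrophenyl puts an aryl group back in the same place. The expectation for compound 4 in this assay is therefore a higher number, quite possibly again beyond what the assay resolves. For compound 4 the expected step is a 6.0-fold higher number from compound 2 to compound 4 (0.78 log units; beyond the scatter). Compound 4 is estimated at 60000 nM, within 10000 nM to 300000 nM.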

Compound 4, half-maximal effective concentration: > 100000 nM
Compound 4: a limit, no number; the forecaster's own chance of this, stated with the estimate: 60%; middle value at least 1.6-fold (0.22 log units) away from the limit.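

On the aromatic nitrogen, 4-nitrophenyl in place of tert-butyl gives an at least 10-fold higher number from compound 2 to compound 4 (1.00 log units; beyond the scatter) in this assay, so the lower number with tert-butyl now holds against two aryl groups, phenyl and 4-nitrophenyl, and not against phenyl alone. The value of compound 4 is a limit, the same one reached by compound 1: the limit of > 100000 nM in this assay, at which 2 of the 4 values shown sit. The step between these two, nitro in place of hydrogen on an aromatic carbon, cannot be read, so the data do not say whether the nitro group changes the number in either direction.

Among the groups shown on this nitrogen, only tert-butyl carries a finite number, so it remains open whether the aryl ring itself drives the higher numbers; methyl, isopropyl or benzyl at the same place would help to separate tert-butyl from the aryl groups. A phenyl ring carrying an amine or a carboxylic acid in place of nitro would test whether any aryl group on this nitrogen can return a number that this assay resolves.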